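A few compounds are considered here, and "the series" means these few. Any claim that something is new, unique, unknown or untested is made for them only; others in the source may bear on it.

Working notes on the series.

Three members of the shared core have been measured in a functional assay on Huh-7 cells (Homo sapiens) for cytotoxicity, read by CCK-8 assay, with a stated time of 72 h; a higher number here means a weaker inhibitor, a lower number a stronger inhibitor. Compound 1 `C=CCn1c(=O)/c(=C\c2cccc(C)c2)[nH]c(=O)/c1=C\c1ccccc1OC` gives 21400 nM in this assay, compound 2 `C=CCn1c(=O)/c(=C\c2cccc(F)c2)[nH]c(=O)/c1=C\c1ccccc1OC` gives 27200 nM, and compound 3 `C=CCn1c(=O)/c(=C\c2ccccc2OC)[nH]c(=O)/c1=C\c1ccccc1OC` gives 21200 nM. Compound 3 stands at the lowest of the three numbers, but the step of a 1.0-fold lower number from compound 1 to compound 3 (0.00 log units; within the scatter) and the step of a 1.3-fold lower number from compound 2 to compound 3 (0.11 log units; within the scatter) both fall within the scatter, so the three values are indistinguishable on this evidence. The remaining measured step, a 1.3-fold higher number from compound 1 to compound 2 (0.10 log units; within the scatter), is likewise within the scatter.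

The next member is compound 4 `C=CCn1c(=O)/c(=C\c2ccccc2Cl)[nH]c(=O)/c1=C\c1ccccc1OC`. Relative to compound 3 the change is chloro in place of methoxy on an aromatic carbon. Among the compounds with values here, no measured step touches this position: every step so far has exchanged the aryl group on the other double-bonded chain carbon, and none of those exchanges moved the number beyond the scatter. Within the data shown here, the change from compound 3 to compound 4 therefore has no direct precedent, and the only guide is that substituent exchanges on an aryl group of this core have so far left this assay unchanged. The expectation for compound 4 is accordingly a step of about a 1.0-fold higher number from compound 3 to compound 4 (0.02 log units; within the scatter), none beyond the scatter. For compound 4 the estimated value in this assay is 22000 nM, with a range from 11000 nM to 45000 nM.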

Compound 4, half-maximal inhibitory concentration: 6400 nM
For compound 4 the middle estimate is 3.4-fold (0.54 log units) above the measured one, outside the stated range (below it).
By their numbers in this assay, from the lowest: compound 4; then compounds 3, 1 and 2 (each within the scatter of the next).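

In this assay, within the data shown here, the aryl group on this double-bonded chain carbon moves the number for the first time: chloro in place of methoxy, on an aromatic carbon ortho to a large group, gives a 3.3-fold lower number from compound 3 to compound 4 (0.52 log units; beyond the scatter) in a series where every earlier step stayed within the scatter. Read as exchanges of the whole aryl group, 2-chlorophenyl also gives a 3.3-fold lower number from compound 1 to compound 4 (0.52 log units; beyond the scatter) and a 4.3-fold lower number from compound 2 to compound 4 (0.63 log units; beyond the scatter), so compound 4 is the strongest inhibitor of the four, while the 3-methylphenyl, 3-fluorophenyl and 2-methoxyphenyl members remain within the scatter of one another. Nothing available accounts for this difference.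

The compounds shown leave open whether the lower number is particular to chloro or would also be seen with bromo, a nitrile or a methyl group at the same place. They also leave open whether chloro would give a similar step on another carbon of this ring, or with an amine in place of the methoxy on the other aryl group.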